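The source may report more compounds than this note shows. Statements on the series, on what has been measured and on what is new or still open speak of the compounds shown alone.

Working notes on the series.

The shared core is that of compound 1 `CSc1nc(NCCCCNc2ccnc3cc(Cl)ccc23)c(C#N)c(-c2ccccc2)n1`, which in an ADME assay on HeLa cells (Homo sapiens) for cytotoxicity, read by microscopy (a lower number here means that less compound is tolerated, a higher number that more compound is tolerated), gives 100000 nM. Compound 2 `CSc1nc(NCCCCNc2ccnc3cc(Cl)ccc23)c(C#N)c(-c2ccc([N+](=O)[O-])cc2)n1` gives 4000 nM, and compound 3 `COc1ccc(-c2nc(SC)nc(NCCCCNc3ccnc4cc(Cl)ccc34)c2C#N)cc1OC` gives 100000 nM. On these numbers compound 3 stands level with compound 1, the two together at the top of the measured set; compound 2 sits furthest from it, as seen in a 25-fold higher number from compound 2 to compound 3 (1.40 log units; beyond the scatter). The single-point steps read a 25-fold lower number from compound 1 to compound 2 (1.40 log units; beyond the scatter) and no change at the digits printed from compound 1 to compound 3 (within the scatter).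

Compound 4 `COc1cc(-c2nc(SC)nc(NCCCCNc3ccnc4cc(Cl)ccc34)c2C#N)cc(OC)c1OC` differs from compound 3 by methoxy in place of hydrogen on an aromatic carbon. Going by the values given here, the step that bears on this is the one from compound 1 to compound 3, where two methoxy groups entered the same phenyl ring and the readout did not move, no change at the digits printed from compound 1 to compound 3 (within the scatter). The large drop in a 25-fold lower number from compound 1 to compound 2 (1.40 log units; beyond the scatter) belongs to a nitro group and does not speak to a further methoxy. One more methoxy on that ring is therefore expected to leave the number where compound 3 has it, with no step beyond the scatter: no change at the digits printed from compound 3 to compound 4 (within the scatter). The estimate for compound 4 is 100000 nM, with a range from 40000 nM to 100000 nM.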

Compound 4, minimum cytotoxic concentration: 20000 nM
For compound 4 the middle estimate is 5.0-fold (0.70 log units) above the measured one; measured number outside the range, below it.
By their numbers in this assay, from the lowest: compound 2; then compound 4; then compounds 1 and 3 (each within the scatter of the next).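

In this assay the ring that took two methoxy groups with no shift does respond to a third one, ortho to a methoxy group and meta to a large group: the readout shows a 5.0-fold lower number from compound 3 to compound 4 (0.70 log units; beyond the scatter). Tolerance of methoxy on this ring therefore does not carry over from two groups to three, and set against the unsubstituted ring the 3,4,5-trimethoxyphenyl group gives a 5.0-fold lower number from compound 1 to compound 4 (0.70 log units; beyond the scatter), while against the 4-nitrophenyl group it gives a 5.0-fold higher number from compound 2 to compound 4 (0.70 log units; beyond the scatter), which places compound 4 between the nitro compound and the pair formed by compound 1 and compound 3. No measurement at hand accounts for this shift.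

On these data alone, whether the drop belongs to methoxy itself or to any group entering at this place remains open, and a hydroxyl, an ethoxy or an amine there would separate those two readings. Also open, as far as these compounds go, is whether the same step appears when the four-carbon linker of the shared core gives way to a longer chain.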